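A few compounds are considered here, and "the series" means these few. Any claim that something is new, unique, unknown or untested is made for them only; others in the source may bear on it.

Of the compounds shown here, two of the shared core have been measured in a functional assay on SN12C cells (Homo sapiens) for cytotoxicity, read by sulforhodamine B assay, with a stated time of 48 h; on this read-out higher numbers stand for weaker inhibition of growth and lower numbers for stronger inhibition of growth. Compound 1 `ClCc1ccc(Cn2cnc3c(Cl)ncnc32)cc1` gives 2340 nM there, and compound 2 `ClCc1ccccc1Cn1cnc2ncnc(Cl)c21` gives 8510 nM. Of these two numbers compound 1 holds the lower one, and the gap between compound 1 and compound 2 lies beyond the scatter of repeated measurements. Compound 3 `ClCc1ccc(Cn2cnc3c(Cl)nc(Cl)nc32)cc1` has not yet been measured. It differs from compound 1 in a single place: chloro in place of hydrogen on an aromatic carbon, a chloro in place of hydrogen on an aromatic carbon. For the measured compounds named here, no pair of measured compounds shows what such a change does on this core, so the direction has to be guessed. The estimate is that a 1.6-fold lower number from compound 1 to compound 3 (0.19 log units; within the scatter) is a small step toward a lower number, one that could still fall within the scatter. Compound 3 is accordingly expected to give 1500 nM in this assay, within a range from 500 nM to 5000 nM.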

Compound 3, concentration for total growth inhibition: 20900 nM
Estimate against measurement, compound 3: 14-fold (1.14 log units) below, outside the stated range (above it).
By their numbers in this assay, from the lowest: compound 1; then compound 2; then compound 3.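

In this assay the change from hydrogen to chloro on the aromatic carbon between two ring nitrogen atoms brings an 8.9-fold higher number from compound 1 to compound 3 (0.95 log units; beyond the scatter) and so weaker inhibition of growth. For the compounds shown here, this is the first reading for this position on the shared core, and it shows that the position is not indifferent to substitution on this read-out: a single entering heavy atom is enough to move the number beyond the scatter. Nothing available here accounts for this loss.

The compounds shown leave open whether an amine, a methoxy group or a methyl group on this carbon would weaken growth inhibition as chloro does, or whether the effect is particular to chloro. They also leave open whether the same change would have a step of similar size on compound 2.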